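A few compounds are considered here, and "the series" means these few. Any claim that something is new, unique, unknown or untested is made for them only; others in the source may bear on it.

Measured so far in an ADME assay on HEK293 cells (Homo sapiens) for antiproliferative activity, read by MTT assay, with a stated time of 24 h; a higher number here means a weaker inhibitor, a lower number a stronger inhibitor:
compound 1 `COc1ccc(-c2cc(C(=O)/C=C/c3ccc(C)cc3)nc3cc(-c4ccccc4)nn23)cc1OC` gives 57400 nM;
compound 2 `COc1ccc(C(=O)/C=C/c2cc(-c3ccc(OC)c(OC)c3)n3nc(-c4ccccc4)cc3n2)cc1` gives 40000 nM;
compound 3 `COc1ccc(C(=O)/C=C/c2cc(-c3ccc(OC)c(OC)c3)n3nc(-c4ccccc4)cc3n2)cc1OC` gives 32500 nM.

All three numbers lie within the usual scatter of one another, so compound 3 cannot be set apart from compound 2 or compound 1 on this evidence: the steps of a 1.4-fold lower number from compound 1 to compound 2 (0.16 log units; within the scatter) and a 1.2-fold lower number from compound 2 to compound 3 (0.09 log units; within the scatter) are both small. Compound 4 `COc1ccc(-c2cc(/C=C/C(=O)c3ccc(Cl)cc3)nc3cc(-c4ccccc4)nn23)cc1OC` differs from compound 3 by 4-chlorophenyl in place of 3,4-dimethoxyphenyl on a carbonyl carbon. Going by the values given here, the only measured step touching that same phenyl is a 1.2-fold lower number from compound 2 to compound 3 (0.09 log units; within the scatter), which changed little; the step of a 1.4-fold lower number from compound 1 to compound 2 (0.16 log units; within the scatter) concerns another part of the molecule and was also small. No measured change moved this assay beyond its scatter, so the step of a 1.2-fold higher number from compound 3 to compound 4 (0.07 log units; within the scatter) is expected to stay within it. Compound 4 is therefore estimated at 38000 nM, with a range from 14000 nM to 100000 nM.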

Compound 4, half-maximal inhibitory concentration: 44100 nM
For compound 4 the middle estimate is 1.2-fold (0.06 log units) below the measured one; the range from low to high includes it.
By their numbers in this assay, from the lowest: compounds 3, 2, 4 and 1 (each within the scatter of the next).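

In this assay, 4-chlorophenyl in place of 3,4-dimethoxyphenyl on a carbonyl carbon gives a 1.4-fold higher number from compound 3 to compound 4 (0.13 log units; within the scatter) and stays within the scatter, as does chloro in place of methoxy, with a 1.1-fold higher number from compound 2 to compound 4 (0.04 log units; within the scatter) on the same ring. Earlier steps only varied methoxy groups here, whereas this ring carries none and the number still does not leave the scatter. The wider change, a 1.3-fold lower number from compound 1 to compound 4 (0.11 log units; within the scatter) as well, remains within it. Going by these compounds, whether an amine or a carboxylic acid on this phenyl would move the number beyond the scatter stays open. No measurement given accounts for how close these numbers lie.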